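This account rests on a few compounds, and the source may have more. Where it says the series, first, only, none or still open, it means among the compounds named here.

Compound 1 `COc1ccc(C2=NN(C3=NC(=O)/C(=C4\C(=O)Nc5ccccc54)S3)C(c3ccc(OC)cc3)C2)cc1` and compound 2 `COc1ccc(C2=NN(C3=NC(=O)/C(=C4\C(=O)Nc5ccc(Br)cc54)S3)C(c3ccc(OC)cc3)C2)cc1` share one core and differ in a single spot: bromo in place of hydrogen on an aromatic carbon. In a functional assay on cells (Cancer cell lines, Homo sapiens) for cytotoxicity, read by sulforhodamine B assay, with a stated time of 48 h (on this read-out lower numbers stand for stronger inhibition of growth and higher numbers for weaker inhibition of growth), compound 1 gives 85200 nM, while compound 2 gives 200 nM, so the change made a large step, a 430-fold lower number from compound 1 to compound 2 (2.63 log units; beyond the scatter).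

Compound 3 `CN(C)c1ccc(C2CC(c3ccccc3)=NN2C2=NC(=O)/C(=C3\C(=O)Nc4ccccc43)S2)cc1` is built on a different core; the difference between the two cores is not broken down here. In this assay compound 3 gives 6370 nM, a number between those of compound 1 and compound 2.

Compound 4 `CN(C)c1ccc(C2CC(c3ccccc3)=NN2C2=NC(=O)/C(=C3\C(=O)Nc4ccc(Br)cc43)S2)cc1` differs from compound 3 in the same way that compound 2 differs from compound 1: bromo in place of hydrogen on an aromatic carbon. Going by the values given here, because the only measured example of this change, a 430-fold lower number from compound 1 to compound 2 (2.63 log units; beyond the scatter), was large, a large step is expected here as well, though a single example on another core leaves the size uncertain and the expected step for compound 4 is set somewhat smaller: a 110-fold lower number from compound 3 to compound 4 (2.03 log units; beyond the scatter). Compound 4 is therefore estimated at 60 nM, with a likely range from 8 nM to 600 nM.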

Compound 4, concentration for 50% growth inhibition: 200 nM
For compound 4 the middle estimate is 3.3-fold (0.52 log units) below the measured one; the measured number falls inside the stated range.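

In this assay the same change again gives a large step, a 32-fold lower number from compound 3 to compound 4 (1.50 log units; beyond the scatter), so on both cores shown, bromo in place of hydrogen on an aromatic carbon goes with stronger inhibition of growth. The direction carries over, but the size does not, and the two steps differ by more than repeated measurements would explain: the same change on two cores in this assay, a 430-fold lower number (2.63 log units; beyond the scatter) from compound 1 to compound 2 and a 32-fold lower number (1.50 log units; beyond the scatter) from compound 3 to compound 4, 13-fold (1.13 log units) apart, beyond the scatter of two such steps. Two cores cannot give a rule for a third, and these numbers do not show which part of either core sets the size of the step.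

As far as these compounds go, it remains open whether this gain belongs to bromo in particular or would also come with chloro, fluoro or a methyl group on the same aromatic carbon. From the compounds shown here alone, it is also open how large the step would be on compounds carrying other groups elsewhere in the molecule, such as an amine or a carboxylic acid.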